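Working notes: from compound 3 to compound 4

The source may report more compounds than this note shows. Statements on the series, on what has been measured and on what is new or still open speak of the compounds shown alone.

In a functional assay on cells (Homo sapiens) for cytotoxicity, read by MTT assay, with a stated time of 24 h (a lower number here means a stronger inhibitor, a higher number a weaker inhibitor), compound 3 `CCCCCCCCCCCCCCNC(=O)[C@H](CO)/N=C/c1cccc(Cl)c1` gives 24100 nM and lies within the scatter of compound 1 `CCCCCCCCCCCCCCNC(=O)[C@H](CO)/N=C/c1ccccc1O` at 19000 nM but clearly under compound 2 `CCCCCCCCCCCCCCNC(=O)[C@H](CO)/N=C/c1cccc([N+](=O)[O-])c1` at 104000 nM in this small set. Within the data shown here, compound 4 `CCCCCCCCCCCCCCNC(=O)[C@H](CO)/N=C/c1ccc([N+](=O)[O-])cc1` brings 4-nitrophenyl in place of 3-chlorophenyl on a carbon with a double bond to nitrogen as its only change. The nearest guide is a 4.3-fold lower number from compound 2 to compound 3 (0.64 log units; beyond the scatter) for chloro in place of nitro on an aromatic carbon, modest but beyond the scatter. Of like size is a 5.5-fold higher number from compound 1 to compound 2 (0.74 log units; beyond the scatter) whereas a 1.3-fold higher number from compound 1 to compound 3 (0.10 log units; within the scatter) stays within the scatter. Among the measured compounds shown here, no measured pair compares 3-nitrophenyl with 4-nitrophenyl, so the nitro effect is carried over with caution. The expected move is a 2.5-fold higher number from compound 3 to compound 4 (0.40 log units; beyond the scatter) in this assay as estimated here. For compound 4 the estimated value is 60000 nM with an expected range from 22000 nM to 160000 nM for now.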

Compound 4, half-maximal inhibitory concentration: 217000 nM
Beside the measured number, compound 4's estimate is 3.6-fold (0.56 log units) below it; the measured number lies above the stated range.
By their numbers in this assay, from the lowest: compounds 1 and 3 (each within the scatter of the next); then compound 2; then compound 4.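

Within this series, in this assay the two nitro isomers separate (a 2.1-fold higher number from compound 2 to compound 4 (0.32 log units; beyond the scatter)), so at this position the place of the nitro on the phenyl ring matters, not only its presence. Among these compounds, the gaps to the other groups are wider, with 3-chlorophenyl (a 9.0-fold higher number from compound 3 to compound 4 (0.95 log units; beyond the scatter)) and with 2-hydroxyphenyl (an 11-fold higher number from compound 1 to compound 4 (1.06 log units; beyond the scatter)), the latter the widest step so far. Nothing measured here explains these steps.

Going by these compounds, whether an amine or a carboxylic acid on the phenyl ring would sit with compound 1 and compound 3 or with compound 4 remains open. So does the effect of a longer chain on the shared core.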